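The compounds below may be only part of what the source reports. "The series", "measured", "known", "first", "only" and "open" are said of these compounds alone.

Measured in an assay (Rattus norvegicus) for inhibition of Fatty-acid amide hydrolase 1 (Homo sapiens); on this read-out lower numbers stand for stronger inhibition and higher numbers for weaker inhibition:

Compound 1 `Nc1ccccc1-c1cnc(C(=O)CCCCCCc2ccccc2)o1`: 750 nM
Compound 2 `COC(=O)c1ccccc1-c1cnc(C(=O)CCCCCCc2ccccc2)o1`: 60 nM
Compound 3 `COc1ccccc1-c1cnc(C(=O)CCCCCCc2ccccc2)o1`: 400 nM

Among these three, compound 1 stands at the highest number; compound 3 sits within the scatter of it, whereas compound 2 lies clearly below it. Compound 4 `NS(=O)(=O)c1ccccc1-c1cnc(C(=O)CCCCCCc2ccccc2)o1` is compound 1 with sulfamoyl in place of amino on an aromatic carbon. Among the measured compounds shown here, two measured steps bear on this change, both replacing the same amino group: a 13-fold lower number from compound 1 to compound 2 (1.10 log units; beyond the scatter) and a 1.9-fold lower number from compound 1 to compound 3 (0.27 log units; within the scatter). The sulfamoyl group, like methoxycarbonyl, carries hydrogen-bond acceptors and more heavy atoms than amino, so compound 4 is expected to follow the direction of compound 2 rather than compound 3, though less far, because a 13-fold lower number from compound 1 to compound 2 (1.10 log units; beyond the scatter) is the larger of the two steps. The expected step is a 3.8-fold lower number from compound 1 to compound 4 (0.57 log units; beyond the scatter). In this assay compound 4 is estimated at 200 nM, within a range of 60 nM to 700 nM.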

Compound 4, inhibition constant: 1500 nM
For compound 4 the middle estimate is 7.5-fold (0.88 log units) below the measured one, outside the stated range (above it).
By their numbers in this assay, from the lowest: compound 2; then compounds 3, 1 and 4 (each within the scatter of the next, the first and the last beyond it).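

In this assay, sulfamoyl in place of amino on this aromatic carbon gives no clear shift (a 2.0-fold higher number from compound 1 to compound 4 (0.30 log units; within the scatter)), so more heavy atoms and hydrogen-bond acceptors do not by themselves reproduce the result of methoxycarbonyl. The choice of group matters here, as sulfamoyl stands well apart from methoxycarbonyl (a 25-fold higher number from compound 2 to compound 4 (1.40 log units; beyond the scatter)) and also from methoxy (a 3.8-fold higher number from compound 3 to compound 4 (0.57 log units; beyond the scatter)). No available evidence accounts for these differences. On these data alone, whether a carboxylic acid, a primary amide or a nitrile on this carbon would match methoxycarbonyl remains open.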